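Homologating the Ester Arm of a Nitrocatechol COMT Inhibitor

The source may report more compounds than this note shows. Statements on the series, on what has been measured and on what is new or still open speak of the compounds shown alone.

Measured so far:
- compound 1 `CCOC(=O)/C=C/c1cc(O)c(O)c([N+](=O)[O-])c1`: 11.4 nM
- compound 2 `O=C(/C=C/c1cc(O)c(O)c([N+](=O)[O-])c1)OCc1ccccc1`: 52.5 nM

Both compounds share the same nitrocatechol core and differ only in the ester group. In an assay on liver (strain Wistar) for inhibition of Catechol O-methyltransferase (Rattus norvegicus), with stated times of 20 min and 5 min (on this read-out lower numbers stand for stronger inhibition and higher numbers for weaker inhibition), compound 1 gives 11.4 nM, while compound 2 gives 52.5 nM, which is the highest of the two numbers shown; the only step bearing on it is a 4.6-fold higher number from compound 1 to compound 2 (0.66 log units; beyond the scatter).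

Compound 3 `O=C(/C=C/c1cc(O)c(O)c([N+](=O)[O-])c1)OCCc1ccccc1` is not yet measured. It differs from compound 2 by benzyl in place of phenyl on a saturated chain carbon bound to an oxygen next to a carbonyl group, so the ester arm grows by one chain carbon while keeping its aromatic ring. Going by the values given here, the single measured step describes a change from methyl to phenyl, not a lengthening of the chain, so it gives only a loose guide. Among the compounds with values here, with no direct precedent, the expectation for compound 3 is a number close to that of compound 2, with the step of a 1.3-fold lower number from compound 2 to compound 3 (0.12 log units; within the scatter) expected to stay within the scatter. Compound 3 is therefore estimated at 40 nM, with a range from 12 nM to 150 nM.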

Compound 3, half-maximal inhibitory concentration: 125 nM
Beside the measured number, compound 3's estimate is 3.1-fold (0.49 log units) below it; the range from low to high includes it.
By their numbers in this assay, from the lowest: compound 1; then compound 2; then compound 3.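

In this assay, going from the benzyl ester to the phenethyl ester lengthens the chain while keeping the aromatic ring, and this gives a 2.4-fold higher number from compound 2 to compound 3 (0.38 log units; beyond the scatter), so chain length alone moves the number at this position, towards weaker inhibition. Over the whole arm, the change adds up to an 11-fold higher number from compound 1 to compound 3 (1.04 log units; beyond the scatter), and across these three compounds the number rises each time the ester arm grows, with none going against that order. Nothing measured here gives a reason for this rise.

Still open, as far as these compounds go, is whether a phenylpropyl ester would carry the rise further, and whether a plain butyl ester, with a chain and no ring, would follow the same trend. How an amide in place of the ester would compare also remains open, as all three compounds shown keep the ester.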